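Swapping a trifluoromethyl for a cyano on a shared core

The compounds below may be only part of what the source reports. "The series", "measured", "known", "first", "only" and "open" are said of these compounds alone.

Compound 1, `Cc1ccc(S/C(=C/c2c[nH]c3ccccc23)C(=O)c2ccc(Br)cc2)cc1`, gives 10000 nM.
Compound 2, `O=C(/C(=C\c1ccc(O)c([N+](=O)[O-])c1)SCc1ccc(Br)cc1)c1ccc(C(F)(F)F)cc1`, gives 10000 nM.
Compound 3, `O=C(/C(=C\c1ccccc1OCc1ccccc1)S(=O)(=O)Cc1ccc(F)cc1)c1ccc(Cl)cc1`, gives 10000 nM.

These three compounds were tested in a functional assay on DU-145 cells (Homo sapiens) for inhibition, read by trypan blue exclusion, with a stated time of 96 h; a lower number here means a stronger inhibitor of growth, a higher number a weaker inhibitor of growth. At the digits reported, compound 2 is level with compound 1 and with compound 3; none of the gaps between these values lies beyond the usual scatter of repeated measurements, so no ordering among them can be read from these numbers.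

The step now considered leads from compound 2 to compound 4, `N#Cc1ccc(C(=O)/C(=C\c2ccc(O)c([N+](=O)[O-])c2)SCc2ccc(Br)cc2)cc1`, which has not yet been measured in this assay. The change is cyano in place of trifluoromethyl on an aromatic carbon. Everything else in the shared core is kept.

Within the data shown here, no step between two measured compounds that differ in a single place is available, so nothing measured shows how this kind of change moves the read-out. With the three measured values all at one level, the plain expectation is that compound 4 will sit at that same level, with the step from compound 2 to compound 4 expected to be no change at the digits printed from compound 2 to compound 4 (within the scatter), that is, nothing beyond the scatter. Compound 4 is therefore estimated at 10000 nM, with a range from 5000 nM to 20000 nM.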

Compound 4, concentration for 50% growth inhibition: 10000 nM
Estimate against measurement, compound 4: no gap at the digits printed, within the range that was stated.
By their numbers in this assay, from the lowest: compounds 1, 2, 3 and 4 (each within the scatter of the next).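

In this assay, among these compounds, this is the first comparison of two compounds that differ in one place only, and the swap gives no change at the digits printed from compound 2 to compound 4 (within the scatter). At this spot on the ring, para to a large group, 4-(trifluoromethyl)phenyl and 4-cyanophenyl therefore cannot be told apart by this read-out, even though the entering cyano has fewer heavy atoms, contains a triple bond and carries a hydrogen-bond acceptor that the trifluoromethyl lacks. Nothing available here gives a reason for this level result.

Going by these compounds, what an amine, a carboxylic acid or a longer chain in this place would do to growth inhibition remains open, since a single swap between two groups says little about the position as a whole. Also open, on these data alone, is whether this swap would give the same result on a different core, as compounds 1 and 3 differ from compound 2 in more than one place and so offer no comparison.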